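Bromo for fluoro on the benzyl ether of compound 2

This account rests on a few compounds, and the source may have more. Where it says the series, first, only, none or still open, it means among the compounds named here.

Two compounds carry a number in an assay on isolated protein (strain Sprague-Dawley) for inhibition of Amine oxidase [flavin-containing] A (Rattus norvegicus), read by spectrophotometry, with a stated time of 5 min, tested at 10 uM (on this read-out lower numbers stand for less inhibition and higher numbers for more inhibition at the one concentration tested (going by the name of the read-out)), so far. Compound 1 `O=c1cc(O)c2ccc(OCc3cccc(Br)c3)cc2o1` gives 0% in this assay. Among the measured compounds shown here, compound 2 `CCOc1cc(=O)oc2cc(OCc3cccc(F)c3)ccc12` gives 25% in this assay, the higher of the two numbers; the gap to compound 1 lies beyond the scatter, but the two differ in more than one place and no single step between them is on hand, so the pair shows only that compound 2 sits higher.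

Compound 3 `CCOc1cc(=O)oc2cc(OCc3cccc(Br)c3)ccc12` is the next member. It differs from compound 2 in one place: bromo in place of fluoro on an aromatic carbon. The same bromo on the same benzyl ether is present in compound 1, but compound 1 also has a different core, so nothing can be read from it about this change on the core of compound 2.

For the measured compounds named here, with no measured step of this kind available, the step from compound 2 to compound 3 is expected to be small, a number 5 percentage points higher from compound 2 to compound 3 (within the scatter), in either direction and most likely within the scatter. Compound 3 is accordingly estimated at 30% in this assay, within a range of 5% to 60%.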

Compound 3, a percentage reported as inhibition, at one concentration (the size of the read-out at that concentration, not a potency): 2.5%
Compound 3: the middle estimate sits 27.5 percentage points above what was measured, and the stated range ends above it.
By their numbers in this assay, from the lowest: compounds 1 and 3 (each within the scatter of the next); then compound 2.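

In this assay, among the compounds shown here, the first single change that can be read, 3-fluorophenyl to 3-bromophenyl on the benzyl ether, gives a number 22.5 percentage points lower from compound 2 to compound 3 (beyond the scatter) and so shows that the read-out is sensitive to which halogen sits on this aromatic carbon, at least with the ethyl ether on the core. With bromo held constant, the second readable change, ethyl in place of hydrogen on the oxygen on the aromatic ring, gives a number 2.5 percentage points higher from compound 1 to compound 3 (within the scatter) and so shows no effect on the core oxygen that stands out from the scatter in this bromo pair. Nothing at hand bears on why the halogen change matters while the ethyl change does not register.

As far as these compounds go, both bromo compounds read close to zero at the one concentration tested, so it remains open whether the ethyl step would also be flat with fluoro on the benzyl ether, where the read-out has more room to fall. Also open, from the compounds shown here alone, is how chloro or a methoxy group would read on this aromatic carbon, and how a longer chain or an amine-bearing chain would read in place of the ethyl group on the oxygen.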